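The source may report more compounds than this note shows. Statements on the series, on what has been measured and on what is new or still open speak of the compounds shown alone.

Compound 1, `CN(C)S(=O)(=O)c1ccc(/C=N/Nc2ncnc3sc(C(C)(C)C)cc23)cc1`, gives 1.42 ug/mL in a functional assay on HCT-116 cells (Homo sapiens) for cytotoxicity, read by MTT assay, with a stated time of 3 days; a lower number here means a stronger inhibitor, a higher number a weaker inhibitor.
Compound 2, `CC(C)(C)c1cc2c(N/N=C/c3ccc(O)cc3)ncnc2s1`, gives 0.844 ug/mL.
Compound 3, `CC(C)(C)c1cc2c(N/N=C/c3ccc(C(=O)O)cc3)ncnc2s1`, gives 9.99 ug/mL.

Among these three, compound 3 stands highest: its number lies a 7.0-fold higher number from compound 1 to compound 3 (0.85 log units; beyond the scatter) and a 12-fold higher number from compound 2 to compound 3 (1.07 log units; beyond the scatter), both beyond the scatter, so it is the weakest inhibitor of the set. Compound 4, `CNCc1ccc(/C=N/Nc2ncnc3sc(C(C)(C)C)cc23)cc1`, has not yet been measured in this assay. It differs from compound 3 in one place: (methylamino)methyl in place of carboxy on an aromatic carbon.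

The measured steps that bear on this change are the two in which carboxy entered. From compound 1, a 7.0-fold higher number from compound 1 to compound 3 (0.85 log units; beyond the scatter); from compound 2, a 12-fold higher number from compound 2 to compound 3 (1.07 log units; beyond the scatter). Removing carboxy is therefore expected to bring the number back down. Within the data shown here, no measured step, however, involves (methylamino)methyl itself, so how far the number falls is uncertain; compound 1 and compound 2 lie within the scatter of each other and mark the region the other groups at this position occupy.

Compound 4 is expected to come in around 1.5 ug/mL, within a range of 0.5 ug/mL to 5 ug/mL, which would mean a step of a 6.7-fold lower number from compound 3 to compound 4 (0.82 log units; beyond the scatter).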

Compound 4, half-maximal inhibitory concentration: 0.056 ug/mL
Compound 4: the middle estimate sits 27-fold (1.43 log units) above what was measured; the whole stated range lies above it.
By their numbers in this assay, from the lowest: compound 4; then compounds 2 and 1 (each within the scatter of the next); then compound 3.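

In this assay, the change from carboxy to (methylamino)methyl gives a 180-fold lower number from compound 3 to compound 4 (2.25 log units; beyond the scatter), the largest step in the set, so removing carboxy here does more than return the number to the level of the other groups. Compound 4 also separates clearly from those groups, with a 15-fold lower number from compound 2 to compound 4 (1.18 log units; beyond the scatter) and a 25-fold lower number from compound 1 to compound 4 (1.40 log units; beyond the scatter); the earlier compounds had shown only that carboxy raised the number, whereas this result shows that a group on this aromatic carbon, para to a large group, can take it well below the level shared by hydroxy and dimethylsulfamoyl. Nothing available here accounts for the size of these steps.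

The compounds shown leave open whether the amine nitrogen itself matters or the (methylamino)methyl group as a whole, a question that hydroxymethyl, with an oxygen in place of the nitrogen, would help to separate. They also leave open how far the low number persists with a primary aminomethyl group, a dimethylaminomethyl group or a longer chain between the ring and the amine.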